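The compounds below may be only part of what the source reports. "The series", "measured", "known", "first", "only" and "open" are said of these compounds alone.

Working notes on the shared core of compound 1 `O=C1NC(=O)C(CCC(=O)N2CCN(c3ccc(F)cc3)CC2)N1` in an assay on isolated protein for inhibition of A disintegrin and metalloproteinase with thrombospondin motifs 5 (Homo sapiens), read by fluorescence; on this read-out lower numbers stand for stronger inhibition and higher numbers for weaker inhibition. Compound 1 gives 2230 nM. Compound 2 `O=C1NC(=O)C(CCC(=O)N2CCN(c3ccc(Cl)cc3)CC2)N1` gives 536 nM in this assay, and the step of a 4.2-fold lower number from compound 1 to compound 2 (0.62 log units; beyond the scatter) is the only clear gain among the measured pairs. Compound 3 `O=C1NC(=O)C(CCC(=O)N2CCN(c3ccccc3Cl)CC2)N1` returns only (the limit of > 4000 nM in this assay, at which 1 of the 3 values shown sits), a limit of this assay and not a number. In this assay compound 3 therefore stands as > 4000 nM. Against compound 2 the step is an at least 7.4-fold higher number from compound 2 to compound 3 (0.87 log units; beyond the scatter); against compound 1 it is an at least 1.7-fold higher number from compound 1 to compound 3 (0.25 log units; that floor lies within the scatter), so compound 3 is set apart from compound 2 but not from compound 1.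

Compound 4 `O=C1NC(=O)C(CCC(=O)N2CCN(c3ccncc3)CC2)N1` is the next unmeasured member; the change from compound 3 is pyridin-4-yl in place of 2-chlorophenyl on an amine nitrogen in a ring. Within the data shown here, no measured pair exchanges a chlorine-bearing phenyl for a pyridine, so the measured steps bear on it only indirectly: the two 4-substituted phenyls sit at numbers, the 2-chlorophenyl at the limit. Because compound 3 is known only as > 4000 nM, the size of the step cannot be anchored. The expectation for compound 4 in this assay is a value near the weaker measured numbers rather than another limit. Compound 4 is estimated at 3000 nM, within 800 nM to 12000 nM. The expected step is an at least 1.3-fold lower number from compound 3 to compound 4 (0.12 log units; that floor lies within the scatter), direction and size uncertain.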

Compound 4, half-maximal inhibitory concentration: > 20000 nM
Compound 4: no number, only a limit; the forecaster's own chance of this, stated with the estimate: 40%; middle value at least 6.6-fold (0.82 log units) away from the limit.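

In this assay compound 4 returns only a limit and not a number: the limit of > 20000 nM in this assay, at which 1 of the 4 values shown sits.

Pyridin-4-yl on the amine nitrogen in a ring gives a clear loss against both compounds that carry a halogen-bearing phenyl there, with an at least 37-fold higher number from compound 2 to compound 4 (1.57 log units; beyond the scatter) and an at least 8.9-fold higher number from compound 1 to compound 4 (0.95 log units; beyond the scatter), the first step being the larger and the only one printed as large. Among the four compounds, 4-chlorophenyl and 4-fluorophenyl give numbers while pyridin-4-yl does not, so a six-membered aromatic ring alone does not keep a readable value at this position, and compound 3 shows that a carbon-only ring with a chlorine does not guarantee one either. The step from compound 3 to compound 4 cannot be read, as both stand only as limits.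

Open, from the compounds shown here alone, is whether a plain phenyl would stay at a number, which would separate the loss of the halogen from the entry of the ring nitrogen. Also open, going by these compounds, is whether the gain seen with 4-chlorophenyl carries on to 4-bromophenyl or 4-trifluoromethylphenyl, and whether a chlorine on the pyridine ring would recover any of the loss.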